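Swapping the Chain on the Ring Nitrogen: Cytotoxicity Outlook

The source may hold more compounds than are shown below. What is called first, only, known or untested is meant among the compounds shown, and "the series" means these compounds.

Compound 1 `CC(C)CCn1nc(-c2cccs2)c(O)c(C2=NS(=O)(=O)c3cc(S(C)(=O)=O)ccc3N2)c1=O` — "not determined" (no result reported)
Compound 2 `CC(C)CCn1nc(CC(C)C)c(O)c(C2=NS(=O)(=O)c3cc(NS(C)(=O)=O)ccc3N2)c1=O` — > 1000 nM
Compound 3 `COCCn1nc(-c2cccs2)c(O)c(C2=NS(=O)(=O)c3cc(NS(C)(=O)=O)ccc3N2)c1=O` — > 1000 nM

In an ADME assay on Huh-7 cells (Homo sapiens) for cytotoxicity, with a stated time of 72 h (on this read-out lower numbers stand for higher toxicity in this test and higher numbers for lower toxicity in this test), compound 1 gives "not determined" (no result reported), so no result was reported. Compound 2 reaches only a limit of this assay, > 1000 nM. Compound 3 likewise reaches only a limit, > 1000 nM. Among the compounds with values here, compound 3 therefore stands at the limit of > 1000 nM in this assay, at which 2 of the 3 values shown sit, and no step between two measured compounds can be read from these numbers.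

Compound 4 `CS(=O)(=O)Nc1ccc2c(c1)S(=O)(=O)N=C(c1c(O)c(-c3cccs3)nn(Cc3ccccn3)c1=O)N2` differs from compound 3 in one place: pyridin-2-yl in place of methoxymethyl on a saturated chain carbon bound to an aromatic nitrogen. Within the data shown here, with no measured step to go by and compound 3 sitting at a limit, no change beyond the scatter is expected from compound 3 to compound 4, estimated as a step that the limit leaves unreadable from compound 3 to compound 4. Compound 4 is thus expected to give about 3000 nM, within 1000 nM to 10000 nM.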

Compound 4, half-maximal cytotoxic concentration: > 1000 nM
Compound 4 ended at the assay's limit; the forecaster's own chance of this, stated with the estimate: 85%; the middle value is on the limit's open side.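

Within the data shown here, compound 3 and compound 4 both stop at a limit of the test, so no step between them can be read: the limit of > 1000 nM in this assay, at which 3 of the 4 values shown sit. As far as these compounds go, whether 2-methoxyethyl and (pyridin-2-yl)methyl differ at all in this assay stays open.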